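Halogenated Aryl Thiourea Expected to Lower Antiproliferative Number

The source may hold more compounds than are shown below. What is called first, only, known or untested is meant among the compounds shown, and "the series" means these compounds.

Three thioureas on one shared core were tested in a functional assay on HepG2 cells (Homo sapiens) for antiproliferative activity, read by MTT assay; a higher number here means a weaker inhibitor, a lower number a stronger inhibitor. Compound 1 `CNC(=O)c1ccc(Oc2cccc(NC(=S)Nc3ccc(C)c(C)c3)c2)nc1` returns only a limit of the assay, > 100000 nM. Compound 2 `CNC(=O)c1ccc(Oc2cccc(NC(=S)Nc3cccc(C(F)(F)F)c3)c2)nc1` gives 23300 nM. Compound 3 `CNC(=O)c1ccc(Oc2cccc(NC(=S)Nc3ccc(OC)cc3)c2)nc1` gives 85300 nM, the highest of the two plain numbers; the step of a 3.7-fold higher number from compound 2 to compound 3 (0.56 log units; beyond the scatter) separates it from the nearest one.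

Compound 4 `CNC(=O)c1ccc(Oc2cccc(NC(=S)Nc3ccc(F)c(Cl)c3)c2)nc1` has not yet been measured. It differs from compound 3 by 3-chloro-4-fluorophenyl in place of 4-methoxyphenyl on an amide-type nitrogen. Within the data shown here, two measured steps bear on this change, both swapping the aryl group on the same nitrogen: an at least 4.2-fold lower number from compound 1 to compound 2 (0.63 log units; beyond the scatter) and a 3.7-fold higher number from compound 2 to compound 3 (0.56 log units; beyond the scatter). In each, the ring carrying the 3-(trifluoromethyl) group gave the lower number, while the 4-methoxyphenyl and 3,4-dimethylphenyl rings gave higher ones. A modest step toward a lower number is therefore expected, a 2.8-fold lower number from compound 3 to compound 4 (0.45 log units; beyond the scatter). In this assay compound 4 is estimated at 30000 nM, with an expected range from 10000 nM to 90000 nM.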

Compound 4, half-maximal inhibitory concentration: > 100000 nM
Compound 4 was reported as a limit (the forecaster's own chance of this, stated with the estimate: 10%); middle value at least 3.3-fold (0.52 log units) from the limit.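

In this assay compound 4 gives > 100000 nM, which is a limit of the assay and not a number, and the same limit recurs in this series: the limit of > 100000 nM in this assay, at which 2 of the 4 values shown sit. Carrying halogens on the ring on this amide-type nitrogen is therefore not enough to give a lower number, since 3-chloro-4-fluorophenyl in place of 3-(trifluoromethyl)phenyl gives an at least 4.2-fold higher number from compound 2 to compound 4 (0.63 log units; beyond the scatter), and the change from 4-methoxyphenyl gives an at least 1.1-fold higher number from compound 3 to compound 4 (0.06 log units; that floor lies within the scatter). Of the four rings, only the 3-(trifluoromethyl)phenyl of compound 2 now stands apart, while the step between compound 1 and compound 4 cannot be read, as both values are limits.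

Going by these compounds, it remains open whether that lower number belongs to the trifluoromethyl group itself or would persist with a nitrile in its place. Whether a ring carrying chlorine alone or fluorine alone would behave like compound 4 is also unresolved.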